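Triazole-linked terpenoid series: aryl variation on the triazole nitrogen

This account rests on a few compounds, and the source may have more. Where it says the series, first, only, none or still open, it means among the compounds named here.

Two members of this series have been measured in a functional assay on MCF7 cells (Homo sapiens) for cytotoxicity, read by MTT assay, with a stated time of 48 h; a higher number here means a weaker inhibitor, a lower number a stronger inhibitor. Compound 1, `CC(C)=CCC/C(C)=C/CC/C(C)=C/CC[C@@H]1[C@@]2(C)CC/C(=N\OCc3cn(-c4cccc(Br)c4)nn3)C(C)(C)[C@@H]2CC[C@@]1(C)O`, carries an oxime ether bearing a bromophenyl-substituted triazole; in this assay compound 1 gives 24800 nM. Compound 2, `CC(C)=CCC/C(C)=C/CC/C(C)=C/CC[C@@H]1[C@@]2(C)C/C(=C\c3ccc(OCc4cn(-c5ccccc5)nn4)cc3)C(=O)C(C)(C)[C@@H]2CC[C@@]1(C)O`, places the triazole on a benzylidene arm through an ether and carries a plain phenyl on the aromatic nitrogen; in this assay compound 2 gives 23000 nM. Compound 2 holds the lower of the two numbers, but the gap to compound 1 lies within the scatter, so the two cannot be ordered.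

Compound 3, `COc1cc(OC)c(-n2cc(COc3ccc(/C=C4\C[C@]5(C)[C@@H](CC/C=C(\C)CC/C=C(\C)CCC=C(C)C)[C@](C)(O)CC[C@H]5C(C)(C)C4=O)cc3)nn2)c(OC)c1`, keeps the core of compound 2 and changes only the aryl on the triazole: 2,4,6-trimethoxyphenyl in place of phenyl on an aromatic nitrogen. Among the measured compounds shown here, no measured pair shows the effect of this kind of change, and the two numbers in hand differ in more than one place, so nothing constrains the direction. The step from compound 2 to compound 3 is expected to be small, a 1.2-fold lower number from compound 2 to compound 3 (0.06 log units; within the scatter), with no direction claimed beyond the scatter. Compound 3 is estimated at 20000 nM, within a range of 7000 nM to 55000 nM.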

Compound 3, half-maximal inhibitory concentration: 13500 nM
Compound 3: middle estimate off by 1.5-fold (0.17 log units), on the high side; measured number inside the range.
By their numbers in this assay, from the lowest: compounds 3, 2 and 1 (each within the scatter of the next).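

In this assay, among the compounds shown here, the first one-place comparison is at the aromatic nitrogen of the triazole, where 2,4,6-trimethoxyphenyl in place of phenyl gives a 1.7-fold lower number from compound 2 to compound 3 (0.23 log units; within the scatter). This position therefore accepts a substituted aryl with 12 heavy atoms and 3 hydrogen-bond acceptors in place of one with 6 heavy atoms and 0 acceptors, with no step beyond the scatter. Nothing available explains this result or connects either aryl group to the cytotoxicity reading.

The compounds shown leave open whether a different kind of group on this aryl ring, such as an amine or a carboxylic acid, would give a step beyond the scatter, and whether a single methoxy group would behave like the three together. The bromophenyl of compound 1 also remains unplaced in this comparison, since compound 1 differs from compound 2 in more than one place and its oxime ether link cannot be separated from its aryl group.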